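The source may report more compounds than this note shows. Statements on the series, on what has been measured and on what is new or still open speak of the compounds shown alone.

Compound 1 `CCCCCN(C1=NCCN1)c1c(Br)cccc1Br` is the starting point. In a physicochemical assay for lipophilicity (a higher number here means a more lipophilic compound, a lower number a more polar compound), compound 1 gives 0.32, the highest of the three numbers measured. Compound 2 `CC(C)N(C1=NCCN1)c1c(Br)cccc1Br` gives -0.82 and compound 3 `C/C=C/CN(C1=NCCN1)c1c(Br)cccc1Br` gives -0.49; the step of a number 1.14 log units lower from compound 1 to compound 2 (beyond the scatter) and the step of a number 0.81 log units lower from compound 1 to compound 3 (beyond the scatter) both lie beyond the scatter, as does the step of a number 0.33 log units higher from compound 2 to compound 3 (beyond the scatter).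

Compound 4 `Brc1cccc(Br)c1N(Cc1ccco1)C1=NCCN1` is not yet measured. It differs from compound 1 by furan-2-yl in place of butyl on a saturated chain carbon bound to a nitrogen on an aromatic ring. Going by the values given here, the step that bears most directly on this change is the one from compound 1 to compound 3, where prop-1-en-1-yl in place of butyl at the same saturated chain carbon lowered the number by a modest amount; the step from compound 1 to compound 2, with a shorter group on the nitrogen, lowered it by a large amount. A group with one five-membered aromatic ring and one hydrogen-bond acceptor in place of butyl is therefore expected to lower this assay by a step of about a number 1.02 log units lower from compound 1 to compound 4 (beyond the scatter). Compound 4 is estimated at -0.7, in the range -1.3 to -0.1.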

Compound 4, distribution coefficient: -0.52
Beside the measured number, compound 4's estimate is 0.18 log units below it; the range from low to high includes it.
By their numbers in this assay, from the lowest: compounds 2, 4 and 3 (each within the scatter of the next, the first and the last beyond it); then compound 1.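

In this assay, furan-2-yl in place of butyl on a saturated chain carbon bound to a nitrogen on an aromatic ring gives a number 0.84 log units lower from compound 1 to compound 4 (beyond the scatter), so a five-membered aromatic ring with one oxygen at this place also stays well short of the pentyl compound. Against prop-1-en-1-yl at the same carbon, the change gives a number 0.03 log units lower from compound 3 to compound 4 (within the scatter), and (furan-2-yl)methyl in place of isopropyl gives a number 0.30 log units higher from compound 2 to compound 4 (within the scatter), so compound 4 cannot be separated from either neighbour, although compounds 2 and 3 stand apart beyond the scatter. Nothing among the data shown explains these numbers.

The compounds shown do not tell whether the ring or its oxygen sets the number for compound 4. A phenyl or thiophen-2-yl group at this carbon, or an amine on the chain, would speak to that.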